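Fluoro-to-methyl swap on the diaryl tail of compound 2

The source may report more compounds than this note shows. Statements on the series, on what has been measured and on what is new or still open speak of the compounds shown alone.

Measured so far:
compound 1, `CC(C(=O)NCc1ccc2ccccc2c1)c1ccc(NS(C)(=O)=O)c(F)c1`: 240 nM
compound 2, `CC(C(=O)NCCC(c1ccc(F)cc1)c1ccc(F)cc1)c1ccc(NS(C)(=O)=O)c(F)c1`: 24.8 nM

Both compounds share the core of compound 1 and were run in a functional assay on CHO cells for antagonist activity at transient receptor potential cation channel subfamily V member 1 (Rattus norvegicus); a lower number here means a stronger inhibitor, a higher number a weaker inhibitor. Compound 2 gives 24.8 nM, the lower of the two numbers; compound 1 gives 240 nM, a gap that lies beyond the scatter. Among the compounds with values here, the two compounds differ in more than one place, so no single step between them can be read off; only the two values themselves are known.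

Compound 3, `Cc1ccc(C(CCNC(=O)C(C)c2ccc(NS(C)(=O)=O)c(F)c2)c2ccc(F)cc2)cc1`, is not yet measured. It differs from compound 2 by methyl in place of fluoro on an aromatic carbon.

Within the data shown here, nothing among the measured compounds speaks to this exchange. For compound 3 the expected step of a 1.0-fold higher number from compound 2 to compound 3 (0.00 log units; within the scatter) is none beyond the scatter in either direction, and compound 3 is estimated at 25 nM, within 10 nM to 65 nM.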

Compound 3, inhibition constant: 31 nM
The estimate for compound 3 lay 1.2-fold (0.09 log units) below the measured number; the measured number falls inside the stated range.
By their numbers in this assay, from the lowest: compounds 2 and 3 (each within the scatter of the next); then compound 1.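

In this assay the exchange of 4-fluorophenyl to 4-methylphenyl gives a 1.3-fold higher number from compound 2 to compound 3 (0.10 log units; within the scatter) and so this position, para to a large group, accepts methyl as well as fluoro with no difference beyond the scatter. Within the data shown here, this is the only single-place comparison so far, and it covers one ring of the diaryl tail, with the other 4-fluorophenyl unchanged in both compounds. No data are available that bear on why the two groups read alike.

On these data alone, whether a chloro, methoxy or amino group at this position would also stay within the scatter of compound 2 remains open, as does the same exchange on the second ring. Among these compounds, compound 1 differs from both compounds in more than one place, so no step to it can be read.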